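Compound 3: fluoro in place of methyl

A few compounds are considered here, and "the series" means these few. Any claim that something is new, unique, unknown or untested is made for them only; others in the source may bear on it.

Measured in an ADME assay on MDCK cells (Canis lupus familiaris) for cytotoxicity, with a stated time of 48 h (on this read-out higher numbers stand for lower toxicity in this test and lower numbers for higher toxicity in this test), so far
compound 1 `C=C(C(=O)OC)[C@@H]1CC[C@H](C)[C@H]2C(=C(C)C(=O)[C@H]2NC(=O)CC#N)C1` at 1450 uM
compound 2 `C=C(C(=O)OC)[C@@H]1CC[C@H](C)[C@H]2C(=C(C)C(=O)[C@H]2NS(=O)(=O)c2ccc(C)cc2)C1` at 61.1 uM

Within the data shown here, compound 2 holds the lower number of the two, and a 24-fold lower number from compound 1 to compound 2 (1.38 log units; beyond the scatter) is the only measured step, large and beyond the scatter. That step exchanges (cyanomethyl)carbonyl for (4-methylphenyl)sulfonyl on an amine nitrogen, so it does not cover the next change. Compound 3 `C=C(C(=O)OC)[C@@H]1CC[C@H](C)[C@H]2C(=C(C)C(=O)[C@H]2NS(=O)(=O)c2ccc(F)cc2)C1` carries fluoro in place of methyl on an aromatic carbon, para to a large group fluoro in place of methyl on an aromatic carbon and is otherwise the same as compound 2. Among the measured compounds shown here, with no measured step for this exchange, the expectation rests on compound 2 at 61.1 uM and no step beyond the scatter is expected in this assay for this pair. The estimated change is a 1.1-fold higher number from compound 2 to compound 3 (0.06 log units; within the scatter) and stays within the scatter. For compound 3 the expected value is 70 uM (30 uM to 160 uM).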

Compound 3, half-maximal toxic concentration: 25.1 uM
Compound 3: middle estimate off by 2.8-fold (0.45 log units), on the high side, and the stated range ends above it.
By their numbers in this assay, from the lowest: compound 3; then compound 2; then compound 1.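

In this assay, the aromatic carbon para to a large group responds to a single-atom exchange: fluoro in place of methyl gives a modest step beyond the scatter (a 2.4-fold lower number from compound 2 to compound 3 (0.39 log units; beyond the scatter)). With the 4-fluorophenyl group, (4-fluorophenyl)sulfonyl in place of (cyanomethyl)carbonyl on the amine nitrogen still gives a large step (a 58-fold lower number from compound 1 to compound 3 (1.76 log units; beyond the scatter)). No evidence is available on what lies behind the difference between the methyl and fluoro compounds. Going by these compounds, whether chloro or methoxy on this carbon lowers the number further remains open. So does the outcome with an amine or a carboxylic acid there.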